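Imidazopyrimidine series: ring-nitrogen substituent swap, piperidine to pyrrolidine

This account rests on a few compounds, and the source may have more. Where it says the series, first, only, none or still open, it means among the compounds named here.

Measured so far:
compound 1 `CN1CCN(c2ccc(Nc3ncc4nc(Nc5ccc(F)cc5)n([C@H]5CCCN(C(=O)CO)C5)c4n3)cc2)CC1`: 1.8 nM
compound 2 `CN1CCN(c2ccc(Nc3ncc4nc(Nc5ccc(F)cc5)n([C@H]5CCCC(NC(=O)OC(C)(C)C)C5)c4n3)cc2)CC1`: 120 nM
compound 3 `CN1CCN(c2ccc(Nc3ncc4nc(Nc5ccccc5)n([C@@H]5CCNC5)c4n3)cc2)CC1`: 65 nM

In a functional assay on HCC827 cells (Homo sapiens) for antiproliferative activity, read by MTT assay, with a stated time of 72 h (on this read-out higher numbers stand for weaker inhibition and lower numbers for stronger inhibition), compound 1 gives 1.8 nM and holds the lowest number of the three; compound 3 stands nearest, and compound 2 furthest, both beyond the scatter. From the compounds shown here alone, compound 4 `CN1CCN(c2ccc(Nc3ncc4nc(Nc5ccc(F)cc5)n([C@@H]5CCN(C(=O)OC(C)(C)C)C5)c4n3)cc2)CC1` is untested. The change: 1-(tert-butoxycarbonyl)pyrrolidin-3-yl in place of 1-((hydroxymethyl)carbonyl)piperidin-3-yl on an aromatic nitrogen. For the measured compounds named here, no step between measured pairs is available, so the size must be judged from the spread alone. Compound 2 with its tert-butoxycarbonyl-bearing substituent gives 120 nM, and compound 3 with a plain pyrrolidinyl gives 65 nM, both far weaker than compound 1. A loss beyond the scatter is therefore expected from compound 1 to compound 4, a 22-fold higher number from compound 1 to compound 4 (1.35 log units; beyond the scatter). Compound 4 is estimated at 40 nM, within 10 nM to 160 nM.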

Compound 4, half-maximal inhibitory concentration: 27 nM
Estimate against measurement, compound 4: 1.5-fold (0.17 log units) above; the range from low to high includes it.
By their numbers in this assay, from the lowest: compound 1; then compound 4; then compounds 3 and 2 (each within the scatter of the next).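

In this assay, the substituent on the aromatic nitrogen proves sensitive: 1-(tert-butoxycarbonyl)pyrrolidin-3-yl in place of 1-((hydroxymethyl)carbonyl)piperidin-3-yl gives a 15-fold higher number from compound 1 to compound 4 (1.18 log units; beyond the scatter) with the rest of the molecule held constant. This step changes ring size and the acyl group together, so it cannot be assigned to either alone. No measured evidence bears on the origin of this loss.

Still open, from the compounds shown here alone, is how a pyrrolidin-3-yl ring carrying the (hydroxymethyl)carbonyl group would compare with compound 1. Going by these compounds, the effect of a methanesulfonyl group on the same ring nitrogen also remains open.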